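The source may report more compounds than this note shows. Statements on the series, on what has been measured and on what is new or still open speak of the compounds shown alone.

Working notes on the series. Compound 1 `CCCCCCCCCCn1cc(-c2nc3ccccc3cc2C)nn1`, compound 2 `Cc1cc2ccccc2nc1-c1cn(-c2ccc(F)cc2)nn1` and compound 3 `CCCCCCCCCCn1cc(-c2nc3ccccc3cc2CC)nn1` have been run in a functional assay on THP-1 cells (Homo sapiens) for cytotoxicity, read by MTT assay, with a stated time of 24 h; a higher number here means a weaker inhibitor, a lower number a stronger inhibitor. Compound 1 gives only a limit of the assay, > 100 ug/mL. Compound 2 likewise gives only a limit of the assay, > 100 ug/mL, so where compound 2 stands is known only as a floor, not as a number. Compound 3 gives 34.3 ug/mL. Within the data shown here, the one step that can be measured is an at least 2.9-fold lower number from compound 1 to compound 3 (0.46 log units; beyond the scatter). Its size is bounded only from below, since (the limit of > 100 ug/mL in this assay, at which 2 of the 3 values shown sit).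

Compound 4 `CCCCCc1cc2ccccc2nc1-c1cn(-c2ccc(F)cc2)nn1` is not yet measured. It differs from compound 2 in one place: butyl in place of hydrogen on a saturated chain carbon bound to an aromatic carbon. Among the measured compounds shown here, the same kind of change, a chain grown on a saturated chain carbon bound to an aromatic carbon, is the only measured step, and it lowered the number in this assay; compound 4 carries a longer chain than the one added in that step. A step downward in this assay is therefore expected, with the limit still a real possibility.

The estimate for compound 4 is 35 ug/mL, expected between 10 ug/mL and 100 ug/mL, which is an expected step of an at least 2.8-fold lower number from compound 2 to compound 4 (0.45 log units; beyond the scatter).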

Compound 4, half-maximal inhibitory concentration: > 100 ug/mL
Compound 4: only a limit was reported; the forecaster's own chance of this, stated with the estimate: 30%; middle value at least 2.8-fold (0.45 log units) away from the limit.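

In this assay, among these compounds, compound 2 and compound 4 each give only a limit, so no step between them can be read: the limit of > 100 ug/mL in this assay, at which 3 of the 4 values shown sit.

The compounds shown leave open whether butyl in place of hydrogen at this place changes the number at all.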